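Sulfonyl-linked coumarin ethers: benzylsulfonyl variant

The source may hold more compounds than are shown below. What is called first, only, known or untested is meant among the compounds shown, and "the series" means these compounds.

Measured so far:
compound 1 `Cc1cc(OCc2nnc(SCc3ccc(Cl)cc3Cl)o2)cc2oc(=O)cc(C)c12` — > 100000 nM
compound 2 `CCCS(=O)(=O)c1nnc(COc2cc(C)c3c(C)cc(=O)oc3c2)o1` — 7070 nM

In a functional assay on MDA-MB-231 cells (Homo sapiens) for antiproliferative activity, read by MTT assay, with a stated time of 24 h (a higher number here means a weaker inhibitor, a lower number a stronger inhibitor), compound 1 reaches only a limit of the assay, > 100000 nM. In this assay, going by the values given here, compound 2 gives 7070 nM, the only firm number so far. Among the compounds with values here, the single measured step, an at least 14-fold lower number from compound 1 to compound 2 (1.15 log units; beyond the scatter), changed two things at once: the sulfanyl became a sulfonyl and the (2,4-dichlorobenzyl) became propyl; as the limit of > 100000 nM in this assay, at which 1 of the 2 values shown sits, records, the starting point is itself a limit, so the step is a lower bound.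

Compound 3 `Cc1cc(OCc2nnc(S(=O)(=O)Cc3ccccc3)o2)cc2oc(=O)cc(C)c12` keeps the sulfonyl of compound 2 and carries phenyl in place of ethyl on a saturated chain carbon bound to a sulfonyl sulfur. Within the data shown here, since the one measured step does not separate the effect of the sulfonyl from that of the shorter chain, the direction of the change is uncertain, and a step within the scatter or a modest rise in number is what is expected. For compound 3 the expected step is a 1.7-fold higher number from compound 2 to compound 3 (0.23 log units; within the scatter). Compound 3 is estimated at 12000 nM, within 3500 nM to 45000 nM.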

Compound 3, half-maximal inhibitory concentration: 7070 nM
Estimate against measurement, compound 3: 1.7-fold (0.23 log units) above, and the stated range covers the measured number.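

In this assay, phenyl in place of ethyl on a saturated chain carbon bound to a sulfonyl sulfur gives no change at the digits printed from compound 2 to compound 3 (within the scatter), so this place carries a benzyl as well as a propyl with the sulfonyl held fixed. The change from the (2,4-dichlorobenzyl)sulfanyl to the benzylsulfonyl gives an at least 14-fold lower number from compound 1 to compound 3 (1.15 log units; beyond the scatter), so a benzyl-type group as such does not go with the loss of measurable activity seen for compound 1. That step still changes the sulfur and the chlorines together, and it starts from a limit, which makes it a lower bound: the limit of > 100000 nM in this assay, at which 1 of the 3 values shown sits.

Open, going by these compounds, is whether the sulfonyl or the loss of the chlorines carries the step, which a benzylsulfanyl or a (2,4-dichlorobenzyl)sulfonyl would separate. Also open, on these data alone, is how a longer chain, or an amine or a carboxylic acid on the benzyl, would read at this place.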